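Swapping the aryl urea cap: from dimethylaminophenyl to methoxyphenyl

A few compounds are considered here, and "the series" means these few. Any claim that something is new, unique, unknown or untested is made for them only; others in the source may bear on it.

Three ureas sharing one core have been measured in a functional assay on MGC-803 cells (Homo sapiens) for antiproliferative activity, read by MTT assay, with a stated time of 48 h; a lower number here means a stronger inhibitor, a higher number a weaker inhibitor. Compound 1 `O=C(Nc1cccc(CNc2nccnc2Cl)c1)Nc1ccccc1F` gives 6440 nM, compound 2 `O=C(Nc1cccc(CNc2nccnc2Cl)c1)Nc1ccc(Cl)c(Cl)c1` gives 4970 nM, and compound 3 `CN(C)c1ccc(NC(=O)Nc2cccc(CNc3nccnc3Cl)c2)cc1` gives 11500 nM. Compound 3 thus carries the highest number of the three: the step of a 1.8-fold higher number from compound 1 to compound 3 (0.25 log units; within the scatter) stays within the scatter, while the step of a 2.3-fold higher number from compound 2 to compound 3 (0.36 log units; beyond the scatter) is modest but lies beyond it, so compound 3 is at best no stronger than its two neighbours and a little weaker than compound 2.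

Compound 4 `COc1ccccc1NC(=O)Nc1cccc(CNc2nccnc2Cl)c1` is the next member. Its change from compound 3 is 2-methoxyphenyl in place of 4-(dimethylamino)phenyl on an amide-type nitrogen. Both measured steps that bear on this are the reverse of what was just described: replacing another aryl group on the amide-type nitrogen by 4-(dimethylamino)phenyl raised the number, in one case within the scatter and in the other modestly beyond it. Taking 4-(dimethylamino)phenyl away again and putting 2-methoxyphenyl in its place would therefore be expected to lower the number somewhat in this assay, most likely by an amount close to the step from compound 3 back to compound 1 rather than anything larger. Compound 4 is accordingly estimated to give 6500 nM, with a plausible span from 3000 nM to 14000 nM, which corresponds to an expected step of a 1.8-fold lower number from compound 3 to compound 4 (0.25 log units; within the scatter).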

Compound 4, half-maximal inhibitory concentration: 12200 nM
Beside the measured number, compound 4's estimate is 1.9-fold (0.27 log units) below it, within the range that was stated.
By their numbers in this assay, from the lowest: compounds 2, 1, 3 and 4 (each within the scatter of the next, the first and the last beyond it).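

In this assay, 2-methoxyphenyl in place of 4-(dimethylamino)phenyl on the amide-type nitrogen gives a 1.1-fold higher number from compound 3 to compound 4 (0.03 log units; within the scatter), so this exchange does not separate the two aryl groups, although they carry different substituents. Methoxy in place of fluoro on an aromatic carbon gives a 1.9-fold higher number from compound 1 to compound 4 (0.28 log units; within the scatter), which likewise cannot be told from no change, while 2-methoxyphenyl in place of 3,4-dichlorophenyl gives a 2.5-fold higher number from compound 2 to compound 4 (0.39 log units; beyond the scatter), a modest step and the widest gap among the four compounds. Nothing available explains why these aryl groups give such closely spaced numbers.

Going by these compounds, all four compounds carry a substituted phenyl on this nitrogen, so the effect of a group of another kind, such as a cyclohexyl ring, a longer alkyl chain or a phenyl bearing a carboxylic acid, remains open. The shared core is also the same throughout, so the compounds shown cannot tell whether a change elsewhere, such as an amine in place of the chlorine on the core, would move the number further than any change to the aryl group has.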